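The source may report more compounds than this note shows. Statements on the series, on what has been measured and on what is new or still open speak of the compounds shown alone.

Within the data shown here, compound 1 `O[C@@H]1[C@@H](OCc2ccccc2)[C@H](OCc2ccccc2)[C@@H](COCc2ccccc2)O[C@H]1Cc1ccccc1` holds the lower of the two numbers so far: in a functional assay on HL-60 cells (Homo sapiens) for antiproliferative activity, read by MTT assay (a higher number here means a weaker inhibitor, a lower number a stronger inhibitor), compound 1 gives 8700 nM, while compound 2 `OC[C@H]1O[C@@H](Cc2ccccc2)[C@H](O)[C@@H](OCc2ccccc2)[C@@H]1OCc1ccccc1` gives 20200 nM, a step of a 2.3-fold higher number from compound 1 to compound 2 (0.37 log units; beyond the scatter). Compound 3 `CC(C)(C)C[C@@H]1O[C@H](COCc2ccccc2)[C@@H](OCc2ccccc2)[C@H](OCc2ccccc2)[C@H]1O` differs from compound 1 by tert-butyl in place of phenyl on a saturated chain carbon bound to a saturated ring carbon. The one measured step, hydrogen in place of benzyl on an oxygen on a saturated carbon, does not touch this change, so no shown step bears on it, and no movement beyond the scatter is expected. Compound 3 is therefore estimated at 8700 nM, within 3000 nM to 25000 nM, an expected step of no change at the digits printed from compound 1 to compound 3 (within the scatter).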

Compound 3, half-maximal inhibitory concentration: "not active" (no number reported)
Compound 3 has no reported number here; there is nothing to compare the estimate with.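

Among these compounds, compound 3 is reported as not active in this assay with no number, so no step from compound 1 can be read. The compounds shown leave open how far benzyl to neopentyl moves the number. Nothing shown accounts for this result.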